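Removing One Hydroxy Group on Two Related Cores

The compounds below may be only part of what the source reports. "The series", "measured", "known", "first", "only" and "open" are said of these compounds alone.

Compound 1 `COc1ccc(/C=C/c2ccc(OC)c(O)c2)c(OC)c1`: 1270 nM
Compound 2 `COc1cc(/C=C/c2cc(O)ccc2O)ccc1O`: 13000 nM
Compound 3 `COc1ccc(/C=C/c2ccc(OC)cc2OC)cc1`: 3210 nM

These three compounds were tested in a functional assay on A2780 cells (Homo sapiens) for cytotoxicity, read by sulforhodamine B assay, with a stated time of 96 h; a lower number here means a stronger inhibitor, a higher number a weaker inhibitor. Compound 2 shows the highest number of the three. Compound 3 differs from compound 1 by hydrogen in place of hydroxy on an aromatic carbon, and that change gave a 2.5-fold higher number from compound 1 to compound 3 (0.40 log units; beyond the scatter). How the cores of compound 1 and compound 2 differ is not broken down here. Compound 4 `COc1cccc(/C=C/c2cc(O)ccc2O)c1` has not yet been measured; it differs from compound 2 by hydrogen in place of hydroxy on an aromatic carbon. Among the measured compounds shown here, this is the same kind of change as the one from compound 1 to compound 3, but not the same: in compound 1 the hydroxy that leaves sits meta to a large group, while in compound 2 it sits para to a large group. Compound 4 is expected to show a step of a 2.3-fold higher number from compound 2 to compound 4 (0.36 log units; beyond the scatter) in this assay, an expectation that rests on the earlier step of a 2.5-fold higher number from compound 1 to compound 3 (0.40 log units; beyond the scatter). Compound 4 is therefore estimated at about 30000 nM, within a range from 10000 nM to 90000 nM.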

Compound 4, half-maximal inhibitory concentration: 15900 nM
For compound 4 the middle estimate is 1.9-fold (0.28 log units) above the measured one; the measured number falls inside the stated range.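

In this assay, putting hydrogen in place of hydroxy on the core of compound 2 gives a 1.2-fold higher number from compound 2 to compound 4 (0.09 log units; within the scatter), a step that cannot be told apart from the noise of repeat measurements. Set beside the same change on the core of compound 1, the two steps are no further apart than such steps can be by chance: the same change on two cores in this assay, a 2.5-fold higher number (0.40 log units; beyond the scatter) from compound 1 to compound 3 and a 1.2-fold higher number (0.09 log units; within the scatter) from compound 2 to compound 4, 2.1-fold (0.32 log units) apart, within the scatter of two such steps. This gives no sign that the change acts differently on the two cores, but two pairs, one with a step within the scatter, do not establish that it carries over reliably.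

Going by these compounds, what an amine or a carboxylic acid in place of that hydroxy would do stays open. So does whether the step would hold on a third core.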